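The source may report more compounds than this note shows. Statements on the series, on what has been measured and on what is new or still open speak of the compounds shown alone.

Series notes. Compound 1 `Nc1nc(-c2ccccc2)nc2sc(-c3ccco3)nc12` is the parent compound. Among the compounds with values here, in an assay on CHO cells for displacement of a labelled ligand from adenosine receptor A3 (Homo sapiens), read by scintillation counting, with a stated time of 3 h (a higher number here means a weaker inhibitor, a lower number a stronger inhibitor), compound 1 gives 15 nM, the highest of the two numbers measured so far. Compound 2 `COc1ccc(-c2nc(N)c3nc(-c4ccco4)sc3n2)cc1` carries methoxy in place of hydrogen on an aromatic carbon, and in this assay compound 2 gives 4.66 nM, so that change produced a 3.2-fold lower number from compound 1 to compound 2 (0.51 log units; beyond the scatter). Compound 3 `N#Cc1cccc(-c2nc(N)c3nc(-c4ccco4)sc3n2)c1` differs from compound 1 by cyano in place of hydrogen on an aromatic carbon. Within the data shown here, the only measured step that bears on it is a 3.2-fold lower number from compound 1 to compound 2 (0.51 log units; beyond the scatter), which involves a different entering group and is therefore only a loose guide. Among the measured compounds shown here, the single substituent change seen so far lowered the number beyond the scatter, so a small lowering is anticipated for compound 3, though not confidently beyond the scatter. Compound 3 is therefore estimated at 11 nM in this assay, with a range from 4 nM to 35 nM. The expected step is a 1.4-fold lower number from compound 1 to compound 3 (0.13 log units; within the scatter).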

Compound 3, inhibition constant: 61.5 nM
Estimate against measurement, compound 3: 5.6-fold (0.75 log units) below; the whole stated range lies below it.
By their numbers in this assay, from the lowest: compound 2; then compound 1; then compound 3.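

In this assay, the cyano group on an aromatic carbon of a six-membered aromatic ring of carbon only, meta to a large group, gives a 4.1-fold higher number from compound 1 to compound 3 (0.61 log units; beyond the scatter) and so runs against a 3.2-fold lower number from compound 1 to compound 2 (0.51 log units; beyond the scatter) in direction. The two single substitutions on the parent therefore do not share one trend, and each step lies beyond the scatter. A lower number cannot be taken as the general outcome of adding a group to this ring, and the data at hand offer no explanation for the rise.

With only methoxy and cyano to compare, the separate contributions of the entering group and its place on the ring remain unresolved. Also open, on these data alone, is how an amine, a carboxylic acid or a longer alkoxy chain would fare at this same position, and how cyano would fare elsewhere on the ring.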